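A few compounds are considered here, and "the series" means these few. Any claim that something is new, unique, unknown or untested is made for them only; others in the source may bear on it.

Compound 1, `O=C1COc2ccc(-n3cc(C[C@H](O)COCCOC[C@@H](O)Cc4ccc(-c5ccccc5)cc4)nn3)cc2N1`; in a functional assay on HCT-116 cells (Homo sapiens) for inhibition, read by MTT assay, with a stated time of 72 h (a higher number here means a weaker inhibitor of growth, a lower number a stronger inhibitor of growth), compound 1 gives 42500 nM. Compound 2, `O=c1[nH]c2ccc(-n3cc(C[C@H](O)COCCOC[C@@H](O)Cc4ccc(-c5ccccc5)cc4)nn3)cc2s1`; in this assay compound 2 gives 9200 nM.

Compound 2 stands lowest of the two numbers; its nearest neighbour is compound 1, and the step went a 4.6-fold lower number from compound 1 to compound 2 (0.66 log units; beyond the scatter). Compound 3, `O[C@H](COCCOC[C@@H](O)Cc1cn(-c2ccc3c(c2)OCCO3)nn1)Cc1ccc(-c2ccccc2)cc1`, is not yet measured. It differs from compound 2 in one place: a group of 10 heavy atoms (8 carbon, 2 oxygen; one six-membered non-aromatic ring with 2 hetero atoms, one six-membered aromatic ring of carbon only) in place of a group of 10 heavy atoms (7 carbon, 1 nitrogen, 1 oxygen, 1 sulfur; one five-membered aromatic ring with 2 hetero atoms, one six-membered aromatic ring of carbon only), on an aromatic nitrogen. For the measured compounds named here, only one measured step bears on this change, a 4.6-fold lower number from compound 1 to compound 2 (0.66 log units; beyond the scatter), in which a group containing one six-membered non-aromatic ring with 2 hetero atoms gave way to the group that now leaves. Because the group entering in compound 3 again contains one six-membered non-aromatic ring with 2 hetero atoms and the step of a 4.6-fold lower number from compound 1 to compound 2 (0.66 log units; beyond the scatter) ran the other way, the reverse direction is expected: a modest rise in the number for compound 3, though with considerable uncertainty. The estimate for compound 3 is therefore 30000 nM, with a range of 8000 nM to 100000 nM, a step of a 3.3-fold higher number from compound 2 to compound 3 (0.51 log units; beyond the scatter).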

Compound 3, concentration for 50% growth inhibition: 16500 nM
Compound 3: the middle estimate sits 1.8-fold (0.26 log units) above what was measured, within the range that was stated.
By their numbers in this assay, from the lowest: compounds 2 and 3 (each within the scatter of the next); then compound 1.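

Compound 3 keeps a six-membered non-aromatic ring with 2 hetero atoms, as compound 1 does, yet the step (a 2.6-fold lower number from compound 1 to compound 3 (0.41 log units; beyond the scatter)) shows that this ring type alone does not bring the number back to that of compound 1. The step (a 1.8-fold higher number from compound 2 to compound 3 (0.25 log units; within the scatter)) shows that in this assay the 2,3-dihydro-1,4-benzodioxin-6-yl group on the aromatic nitrogen cannot be told apart from the group it replaces, although that group carries a hydrogen-bond donor and this one carries none. Nothing given here explains why the numbers fall this way.

From the compounds shown here alone, what sets the group of compound 1 apart therefore stays open. Also open, going by these compounds, is whether a second fused ring matters at all, which a plain phenyl group or a phenyl group bearing an amine on the same nitrogen would test.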